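The compounds below may be only part of what the source reports. "The series", "measured", "known", "first", "only" and "open" are said of these compounds alone.

Measured compounds in this set:
compound 1 `COC1=C(CC(C)(C)CNC(=O)c2ccccc2)C(=O)c2ccccc2C1=O` — 12300 nM
compound 2 `COC1=C(CC(C)(C)CNC(=O)c2ccccc2OC)C(=O)c2ccccc2C1=O` — 27300 nM
compound 3 `COC1=C(CC(C)(C)CNC(=O)c2ccc3ccccc3c2)C(=O)c2ccccc2C1=O` — 36000 nM

In an ADME assay on Vero cells (Chlorocebus sabaeus) for cytotoxicity, read by fluorescence, with a stated time of 4 days (on this read-out lower numbers stand for stronger inhibition and higher numbers for weaker inhibition), compound 3 stands at the high end of the three numbers: the step of a 2.9-fold higher number from compound 1 to compound 3 (0.47 log units; beyond the scatter) is beyond the scatter, while the step of a 1.3-fold higher number from compound 2 to compound 3 (0.12 log units; within the scatter) is within it. Compound 4 `COC1=C(CC(C)(C)CNC(=O)c2ccc3ccccc3c2OC)C(=O)c2ccccc2C1=O` differs from compound 3 by methoxy in place of hydrogen on an aromatic carbon. Among the measured compounds shown here, the one measured step of the same kind, methoxy entering for hydrogen on an aromatic carbon, is a 2.2-fold higher number from compound 1 to compound 2 (0.35 log units; beyond the scatter), a modest rise. On that basis a step of similar size and direction is expected, a 1.8-fold higher number from compound 3 to compound 4 (0.26 log units; within the scatter). Compound 4 is therefore estimated at 65000 nM, with a range of 30000 nM to 140000 nM.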

Compound 4, half-maximal inhibitory concentration: 60600 nM
Compound 4: the middle estimate sits 1.1-fold (0.03 log units) above what was measured; measured number inside the range.
By their numbers in this assay, from the lowest: compound 1; then compounds 2, 3 and 4 (each within the scatter of the next, the first and the last beyond it).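

In this assay, methoxy in place of hydrogen on an aromatic carbon now has a reading on a second core, ortho to a fused ring, with a 1.7-fold higher number from compound 3 to compound 4 (0.23 log units; within the scatter). Taken alone, this step does not separate compound 4 from compound 3, but the two readings of the change do not separate from each other either: the same change on two cores in this assay, a 2.2-fold higher number (0.35 log units; beyond the scatter) from compound 1 to compound 2 and a 1.7-fold higher number (0.23 log units; within the scatter) from compound 3 to compound 4, 1.3-fold (0.12 log units) apart, within the scatter of two such steps

Going by these compounds, whether an amine, a hydroxyl or a longer ethoxy chain at this position would give a step of the same size stays open. So does whether any such step would carry over to other cores.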